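This account rests on a few compounds, and the source may have more. Where it says the series, first, only, none or still open, it means among the compounds named here.

Measured in a functional assay on MDA-MB-231 cells (Homo sapiens) for antiproliferative activity, with a stated time of 5 days; a higher number here means a weaker inhibitor, a lower number a stronger inhibitor:
- compound 1 `CC1OC2(C=CC(=O)C=C2)N(c2nc(-c3ccc4ccccc4c3)nn2-c2ccccc2)C1=O`: 70 nM
- compound 2 `COc1ccc(-n2nc(-c3ccc4ccccc4c3)nc2N2C(=O)C(C)OC23C=CC(=O)C=C3)cc1`: 50 nM

In this assay, among the measured compounds shown here, compound 1 gives 70 nM, the higher of the two numbers, though the only measured step, a 1.4-fold lower number from compound 1 to compound 2 (0.15 log units; within the scatter), does not separate it from its neighbour. Compound 3 `O=C1C=CC2(C=C1)OCC(=O)N2c1nc(-c2ccc3ccccc3c2)nn1-c1ccccc1` differs from compound 1 as follows: hydrogen in place of methyl on a saturated ring carbon. That one measured step is methoxy in place of hydrogen on an aromatic carbon, elsewhere in the molecule, so no measurement covers this change directly. The expected step is a 1.1-fold higher number from compound 1 to compound 3 (0.06 log units; within the scatter), with no shift beyond the scatter anticipated. For compound 3 the estimate is 80 nM, with an expected range of 30 nM to 220 nM.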

Compound 3, half-maximal inhibitory concentration: 70 nM
The estimate for compound 3 lay 1.1-fold (0.06 log units) above the measured number; low and high end bracket the measured number.
By their numbers in this assay, from the lowest: compounds 2, 1 and 3 (each within the scatter of the next).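

Hydrogen in place of methyl on the saturated ring carbon, next to the ring oxygen, gives no shift beyond the scatter in this assay (no change at the digits printed from compound 1 to compound 3 (within the scatter)). The methyl is thus dispensable for this read-out in this compound pair, which compound 2, changed only on an aromatic carbon, could not show. No supporting measurement explains this result.

As far as these compounds go, whether a larger group on this carbon, such as ethyl, phenyl or hydroxymethyl, would be tolerated remains open. Also open, from the compounds shown here alone, is how methoxy on the aromatic ring behaves without the methyl.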